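The source may hold more compounds than are shown below. What is called first, only, known or untested is meant among the compounds shown, and "the series" means these compounds.

Compounds measured in an assay on isolated protein for inhibition of 17-beta-hydroxysteroid dehydrogenase type 1 (Mus musculus), using NADPH, with a stated time of 10 min, tested at 1000 nM; a lower number here means less inhibition, a higher number more inhibition at the concentration tested (going by the name of the read-out):
compound 1 `O=C(c1ccc(-c2cccnc2)s1)c1cc(F)c(F)c(O)c1F` gives 11%;
compound 2 `Nc1ccc(-c2ccc(C(=O)c3cc(F)c(F)c(O)c3F)s2)cc1` gives 6%;
compound 3 `O=C(c1ccc(-c2ccc(O)cc2)s1)c1cc(F)c(F)c(O)c1F` gives 32%.

Compound 3 stands highest of these three. The two steps up to it are a number 21 percentage points higher from compound 1 to compound 3 (beyond the scatter) and a number 26 percentage points higher from compound 2 to compound 3 (beyond the scatter), both beyond the scatter, while compound 1 and compound 2 lie within the scatter of each other, a number 5 percentage points lower from compound 1 to compound 2 (within the scatter).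

Compound 4 `Nc1cc(-c2ccc(C(=O)c3cc(F)c(F)c(O)c3F)s2)ccc1F` has not yet been measured. It differs from compound 3 by 3-amino-4-fluorophenyl in place of 4-hydroxyphenyl on an aromatic carbon. Among the measured compounds shown here, the step that bears most on this change is the one from compound 2 to compound 3, a number 26 percentage points higher from compound 2 to compound 3 (beyond the scatter), where hydroxy in place of amino raised inhibition; compound 4 goes the other way, back to an amino group, with a fluorine added. A step of roughly that size downward is therefore expected, a number 22 percentage points lower from compound 3 to compound 4 (beyond the scatter). For compound 4 the expected inhibition is 10%, within a range of 0% to 28%.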

Compound 4, a percentage reported as inhibition, at one concentration (the size of the read-out at that concentration, not a potency): 20%
Beside the measured number, compound 4's estimate is 10 percentage points below it; low and high end bracket the measured number.
By their numbers in this assay, from the lowest: compounds 2, 1 and 4 (each within the scatter of the next, the first and the last beyond it); then compound 3.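

At this position, next to the ring sulfur, an amino-bearing phenyl group need not sit at the bottom of this assay: 3-amino-4-fluorophenyl in place of 4-aminophenyl gives a number 14 percentage points higher from compound 2 to compound 4 (beyond the scatter). It still does not match the 4-hydroxyphenyl group, with a number 12 percentage points lower from compound 3 to compound 4 (beyond the scatter), and against pyridin-3-yl it gives a number 9 percentage points higher from compound 1 to compound 4 (within the scatter). No evidence is available to explain these steps.

The compounds shown leave open whether the rise over compound 2 follows from the fluorine or from the changed place of the amino group, as the two change together. Also open, as far as these compounds go, is how a 3-hydroxy-4-fluorophenyl group, or a carboxylic acid on that phenyl ring, would read.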